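The compounds below may be only part of what the source reports. "The series", "measured", "known", "first", "only" and "open" are said of these compounds alone.

Measured in an in vivo ADME assay on the whole organism (plasma) with Mus musculus as the target, at a dose of 100 mg/kg by the oral route; on this read-out lower numbers stand for lower exposure and higher numbers for higher exposure at the dose given:

- Compound 1 `C/C=C(\c1ccccc1)c1ccc2nc(N)n(S(=O)(=O)C(C)C)c2c1`: 14300 nM
- Compound 2 `C#C/C=C(/c1ccc2nc(N)n(S(=O)(=O)C(C)C)c2c1)c1ccccc1F`: 24000 nM
- Compound 3 `C#C/C=C(/c1ccc2nc(N)n(S(=O)(=O)C(C)C)c2c1)c1cc(F)ccc1F`: 23200 nM

Compound 3 at 23200 nM stands within the scatter of both compound 2 and compound 1, so the three values do not separate. Next is compound 4 `C#C/C=C(\c1ccc(C)cc1)c1ccc2nc(N)n(S(=O)(=O)C(C)C)c2c1`, where 4-methylphenyl replaces 2,5-difluorophenyl on a double-bonded chain carbon bound to an aromatic carbon and a double-bonded chain carbon: 4-methylphenyl in place of 2,5-difluorophenyl on a double-bonded chain carbon bound to an aromatic carbon and a double-bonded chain carbon. Going by the values given here, the only measured step between close neighbours is a 1.0-fold lower number from compound 2 to compound 3 (0.01 log units; within the scatter) and it concerns fluoro in place of hydrogen on an aromatic carbon. Among the compounds with values here, that step bears only in part on the change, since no measured pair carries a methyl group or loses both fluoro groups. The flat response to fluoro and the narrow spread of all three values give no reason to expect a large move. Expected in this assay is a 1.2-fold lower number from compound 3 to compound 4 (0.06 log units; within the scatter) and thus no step beyond the scatter. For compound 4 the estimated value is 20000 nM with an expected range from 9000 nM to 42000 nM as the working bounds.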

Compound 4, maximal plasma concentration: 1610 nM
Estimate against measurement, compound 4: 12-fold (1.09 log units) above, outside the stated range (below it).
By their numbers in this assay, from the lowest: compound 4; then compounds 1, 3 and 2 (each within the scatter of the next).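

At the place on a double-bonded chain carbon bound to an aromatic carbon and a double-bonded chain carbon, exposure in this assay depends strongly on the aryl group: 4-methylphenyl in place of 2,5-difluorophenyl gives a 14-fold lower number from compound 3 to compound 4 (1.16 log units; beyond the scatter) and 4-methylphenyl in place of 2-fluorophenyl gives a 15-fold lower number from compound 2 to compound 4 (1.17 log units; beyond the scatter). The fluoro change alone gave only a 1.0-fold lower number from compound 2 to compound 3 (0.01 log units; within the scatter), so the flat response seen there does not extend to a change from a fluorophenyl group to 4-methylphenyl. Nothing measured on these compounds accounts for the drop.

From the compounds shown here alone, compound 4 adds the methyl group and loses fluoro in one change, so the share of each in the drop stays open. Going by these compounds, how a methoxy group or a chloro group would read on this aryl ring at this place also stays open.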